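Fluoro for trifluoromethyl on the aryl of a thiophene ester

The compounds below may be only part of what the source reports. "The series", "measured", "known", "first", "only" and "open" are said of these compounds alone.

Two members of the series have been measured in an assay on isolated protein for inhibition of protein kinase C zeta type (Homo sapiens), with stated times of 1 h and 2.5 min, tested at 30 uM; a lower number here means less inhibition, a higher number more inhibition at the concentration tested (going by the name of the read-out). Compound 1 `Cc1ccc(-c2csc(N)c2C(=O)OCc2ccccc2)cc1` gives 60% in this assay. Compound 2 `Nc1scc(-c2cccc(C(F)(F)F)c2)c1C(=O)OCc1ccccc1` gives 29% in this assay, which is the lower of the two numbers; the gap to compound 1 is beyond the usual scatter of this assay, so the inhibition of compound 2 in this assay is lower than that of compound 1 on the numbers shown. Among the measured compounds shown here, no single-point step between measured compounds is available, so the two values show only this ordering.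

Compound 3 `Nc1scc(-c2cccc(F)c2)c1C(=O)OCc1ccccc1` is the next compound to be measured in this assay. It differs from compound 2 in one place: fluoro in place of trifluoromethyl on an aromatic carbon. For the measured compounds named here, no measured pair reports the effect of this change, so the direction rests on compound 2 alone. A modest rise in inhibition from compound 2 to compound 3 is expected, of about a number 11 percentage points higher from compound 2 to compound 3 (beyond the scatter), though a step within the scatter is also plausible. Compound 3 is estimated to give 40% in this assay, within a range from 15% to 65%.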

Compound 3, a percentage reported as inhibition, at one concentration (the size of the read-out at that concentration, not a potency): 53%
The estimate for compound 3 lay 13 percentage points below the measured number; the range from low to high includes it.
By their numbers in this assay, from the lowest: compound 2; then compounds 3 and 1 (each within the scatter of the next).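

Notes on the aromatic substituent: in this assay this aromatic carbon responds to the group it carries, with fluoro in place of trifluoromethyl giving a number 24 percentage points higher from compound 2 to compound 3 (beyond the scatter), the first single-place step in the series to show a change beyond the scatter. The second step, with 3-fluorophenyl in place of 4-methylphenyl, gives a number 7 percentage points lower from compound 1 to compound 3 (within the scatter), so these two aryl groups cannot be told apart in this read-out even though their substituents and substitution places differ. The data in hand give no measurement that accounts for either step.

As far as these compounds go, each number is a percentage at one concentration rather than a potency, so the size of the trifluoromethyl-to-fluoro step on a potency scale stays open, as does whether the two aryl groups would remain indistinguishable on such a scale. Also open, from the compounds shown here alone, is how other groups on the same aromatic carbon would compare with fluoro and trifluoromethyl, for example chloro, methoxy, a nitrile, an amine or a carboxylic acid, and whether the step seen here would hold on a different aromatic carbon of the ring.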